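This account rests on a few compounds, and the source may have more. Where it says the series, first, only, none or still open, it means among the compounds named here.

Measured so far in an ADME assay on SW480 cells (Homo sapiens) for cytotoxicity, read by MTT assay, with a stated time of 72 h; on this read-out lower numbers stand for stronger inhibition and higher numbers for weaker inhibition:
compound 1 `CCOc1ccc(NC(=O)c2cccc(/C=C3\CC(=O)N(c4ccccc4)C3=O)c2)cc1` gives 91500 nM
compound 2 `Cc1ccc(NC(=O)c2cccc(/C=C3\CC(=O)N(c4ccccc4)C3=O)c2)cc1C` gives > 100000 nM, which is a limit of the measurement rather than a number
compound 3 `COc1ccc(OC)c(NC(=O)c2cccc(/C=C3\CC(=O)N(c4ccccc4)C3=O)c2)c1` gives > 100000 nM, likewise only a limit

Compound 3 thus stands at the limit of > 100000 nM in this assay, at which 2 of the 3 values shown sit; its true number is not known, only that it lies beyond that limit. Compound 4 `Cc1cccc(NC(=O)c2cccc(/C=C3\CC(=O)N(c4ccccc4)C3=O)c2)c1` differs from it in one place: 3-methylphenyl in place of 2,5-dimethoxyphenyl on an amide-type nitrogen. The measured steps that bear on this change are an at least 1.0-fold higher number from compound 1 to compound 2 (0.03 log units; that floor lies within the scatter) and an at least 1.0-fold higher number from compound 1 to compound 3 (0.03 log units; that floor lies within the scatter), both floors that lie within the scatter, while a step that the two limits leave unreadable from compound 2 to compound 3. None of them shows a change beyond the scatter, so for compound 4 no step beyond the scatter is expected in this assay, and the estimated step that the limit leaves unreadable from compound 3 to compound 4 reflects that. Compound 4 is therefore expected to give about 110000 nM, within a range from 55000 nM to 250000 nM.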

Compound 4, half-maximal inhibitory concentration: > 100000 nM
Compound 4 ended at the assay's limit (the forecaster's own chance of this, stated with the estimate: 60%); the middle value is on the limit's open side.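

In this assay, 3-methylphenyl on the amide-type nitrogen, a ring with no hydrogen-bond acceptors, sits at the same limit as 2,5-dimethoxyphenyl and 3,4-dimethylphenyl, so three different rings now end there: the limit of > 100000 nM in this assay, at which 3 of the 4 values shown sit.

Among these compounds, the one readable step is an at least 1.0-fold higher number from compound 1 to compound 4 (0.03 log units; that floor lies within the scatter), and the steps among the compounds at the limit cannot be read.

On these data alone, how far these compounds lie beyond the limit stays open. So does whether a phenyl ring carrying an amine or a carboxylic acid at this place would give a clearly lower number.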